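A few compounds are considered here, and "the series" means these few. Any claim that something is new, unique, unknown or untested is made for them only; others in the source may bear on it.

In an assay on HEK293 cells for positive allosteric modulation of metabotropic glutamate receptor 5 (Homo sapiens), read by FLIPR, with a stated time of 1 h (on this read-out higher numbers stand for an effect only at larger amounts of compound and lower numbers for an effect already at smaller amounts), compound 3 `O=C(C1CCOCC1)N1CCc2nc(C#Cc3ccccc3)sc2C1` gives 290 nM, the highest number of the three measured compounds. Compound 1 `CC1CC1C(=O)N1CCc2nc(C#Cc3ccccc3)sc2C1` gives 9.4 nM and compound 2 `O=C(C1CCCC1)N1CCc2nc(C#Cc3ccccc3)sc2C1` gives 19 nM in the same assay. The steps of a 31-fold higher number from compound 1 to compound 3 (1.49 log units; beyond the scatter) and a 15-fold higher number from compound 2 to compound 3 (1.18 log units; beyond the scatter) are both large, while a 2.0-fold higher number from compound 1 to compound 2 (0.31 log units; beyond the scatter) is modest. Compound 4 `O=C(CC1CCOCC1)N1CCc2nc(C#Cc3ccccc3)sc2C1` carries (oxan-4-yl)methyl in place of oxan-4-yl on a carbonyl carbon. For the measured compounds named here, none of the measured steps lengthens the group on the carbonyl carbon; each of them swaps one ring sitting directly on that carbon for another, and both steps ending at compound 3 only show that the oxan-4-yl ring gives the highest number among the three groups tried there. Going by the values given here, the step from compound 3 to compound 4 thus has no direct precedent, and a change no larger than a small one, in either direction, is expected, with compound 4 staying nearest compound 3. Compound 4 is estimated at 400 nM, with a range of 100 nM to 1600 nM, meaning an expected step of a 1.4-fold higher number from compound 3 to compound 4 (0.14 log units; within the scatter).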

Compound 4, half-maximal effective concentration: 470 nM
For compound 4 the middle estimate is 1.2-fold (0.07 log units) below the measured one, within the range that was stated.
By their numbers in this assay, from the lowest: compound 1; then compound 2; then compounds 3 and 4 (each within the scatter of the next).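

In this assay, (oxan-4-yl)methyl in place of oxan-4-yl on a carbonyl carbon is the first step shown that lengthens the group at this position, and it gives a 1.6-fold higher number from compound 3 to compound 4 (0.21 log units; within the scatter), so compounds 3 and 4 cannot be told apart here. The separation from the other two groups remains, with a 25-fold higher number from compound 2 to compound 4 (1.39 log units; beyond the scatter) and a 50-fold higher number from compound 1 to compound 4 (1.70 log units; beyond the scatter), both large. Nothing available bears on why these numbers differ.

As far as these compounds go, whether the large steps follow the ring oxygen or the ring size stays open, and cyclohexyl on the carbonyl carbon would separate the two. Also open, from the compounds shown here alone, is whether cyclopentylmethyl would match cyclopentyl as compound 4 matches compound 3, and whether a longer chain to the oxan-4-yl ring would give a number close to those of compounds 3 and 4.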